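The compounds below may be only part of what the source reports. "The series", "measured", "known", "first", "only" and "open" are said of these compounds alone.

Measured compounds:
- compound 1, `O=C(NCCCCc1ccccc1)n1cnc2ccccc21`, in an assay on HEK293 cells for inhibition of acid ceramidase (Homo sapiens), read by fluorescence, with stated times of 30 min and 1 h (a higher number here means a weaker inhibitor, a lower number a stronger inhibitor), gives 2.5 nM.
- compound 2, `Nc1nc2ccccc2n1C(=O)NCCCCc1ccccc1`, in this assay gives 0.9 nM.

Compound 2 has the lowest number of the two measured in this assay. Going by the values given here, its nearest neighbour is compound 1, and the single step between them is a 2.8-fold lower number from compound 1 to compound 2 (0.44 log units; beyond the scatter), described as amino in place of hydrogen on an aromatic carbon of the shared core.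

Compound 3 is `Cc1nc2ccccc2n1C(=O)NCCCCc1ccccc1`. It differs from compound 2 by methyl in place of amino on an aromatic carbon. Among the compounds with values here, the only measured step that bears on this position is the one from compound 1 to compound 2, which shows that putting an amino group there lowers the number modestly. Replacing that amino group with a methyl group removes what the amino group brought, so the number is expected to move back toward that of compound 1, though methyl is not hydrogen, and the change could also stay within the scatter. The expected step is therefore a small rise, a 2.2-fold higher number from compound 2 to compound 3 (0.35 log units; beyond the scatter). For compound 3 in this assay the estimate is 2 nM, with a plausible range from 0.7 nM to 6 nM.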

Compound 3, half-maximal inhibitory concentration in the acid ceramidase assay: 1 nM
The estimate for compound 3 lay 2.0-fold (0.30 log units) above the measured number, within the range that was stated.
By their numbers in the acid ceramidase assay, from the lowest: compounds 2 and 3 (each within the scatter of the next); then compound 1.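

In the acid ceramidase assay, the gain seen with amino on this aromatic carbon between two ring nitrogen atoms does not depend on amino itself (a 1.1-fold higher number from compound 2 to compound 3 (0.05 log units; within the scatter)), even though methyl carries none of the hydrogen-bond donors or acceptors counted on amino. Methyl in place of hydrogen also lowers the number (a 2.5-fold lower number from compound 1 to compound 3 (0.40 log units; beyond the scatter)), so among these compounds both amino and methyl at this position give a lower number than hydrogen, and neither can be ranked above the other. The swap from amino to methyl does separate the two compounds in a physicochemical assay for metabolic stability, read by HPLC, at pH 4.5, tested at 10 uM (on this read-out lower numbers stand for a shorter-lived compound and higher numbers for a longer-lived compound), where compound 2 gives 0.717 h and compound 3 gives 0.133 h, so compound 3 is the shorter-lived: (the measured half-life of compound 2, 0.717 h, and of compound 3, 0.133 h, a 5.4-fold lower number (0.73 log units; beyond the scatter)).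

On these data alone, what stays open is whether a larger group at this position, such as ethyl or phenyl, or a different small one, such as hydroxyl or chlorine, would keep the number in the acid ceramidase assay this low. As far as these compounds go, it is also open whether a methoxy or dimethylamino group here would keep the half-life of compound 2 or shorten it as methyl does.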